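The source may report more compounds than this note shows. Statements on the series, on what has been measured and on what is new or still open speak of the compounds shown alone.

Measured so far in a functional assay on B16-F10 cells (Mus musculus) for antiproliferative activity, read by MTT assay, with a stated time of 48 h; on this read-out higher numbers stand for weaker inhibition and lower numbers for stronger inhibition:

- Compound 1 `CCCCCCCCCCCCOc1ccc(C(=O)/C=C/c2c(/C=C/c3ccc(OC)cc3)cc(OC)cc2OC)cc1`: 12.7 ug/mL
- Compound 2 `COc1ccc(/C=C/c2cc(OC)cc(OC)c2/C=C/C(=O)c2ccc(C)cc2)cc1`: 5.3 ug/mL

Compound 2 has the lower of these two numbers, which makes it the stronger inhibitor of the pair. The gap up to compound 1 lies beyond the usual scatter of repeated measurements.

The next compound to be tested is compound 3 `CCCCOc1ccc(C(=O)/C=C/c2c(/C=C/c3ccc(OC)cc3)cc(OC)cc2OC)cc1`. It keeps the rest of compound 2 and changes one group, 4-methylphenyl to 4-butoxyphenyl: butoxy in place of methyl on an aromatic carbon. Butoxy takes the place of methyl on an aromatic carbon, para to a large group.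

Within the data shown here, no measured pair shows this change on its own, so any forecast is loose. Among the measured compounds shown here, the only guides are compound 2 at 5.3 ug/mL and compound 1 at 12.7 ug/mL, and the expectation is that compound 3 falls between them. In this assay, a small step toward weaker inhibition is expected, probably not beyond the scatter. The estimate is a 1.4-fold higher number from compound 2 to compound 3 (0.15 log units; within the scatter). The expected value for compound 3 is 7.5 ug/mL, with an estimated range of 3.5 ug/mL to 15 ug/mL.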

Compound 3, half-maximal inhibitory concentration: 5.3 ug/mL
Compound 3: middle estimate off by 1.4-fold (0.15 log units), on the high side; the range from low to high includes it.
By their numbers in this assay, from the lowest: compounds 2 and 3 (each within the scatter of the next); then compound 1.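

In this assay, putting butoxy in place of methyl on this aromatic carbon, para to a large group, gives no change at the digits printed from compound 2 to compound 3 (within the scatter) and so leaves the read-out where it was, which shows that this position accepts an oxygen-linked butyl chain as readily as a single methyl carbon. The length of the chain at the same position does matter, as the other comparison gives a 2.4-fold lower number from compound 1 to compound 3 (0.38 log units; beyond the scatter) for hydrogen in place of octyl on the saturated chain, with the oxygen link and the rest of the molecule kept the same. The numbers come with no other measurement that could explain either result.

The compounds shown leave open where between butoxy and the much longer chain of compound 1 the number begins to rise, which a hexyloxy or an octyloxy chain at this position would help to locate. They also leave open whether a chain ending in an amine or a carboxylic acid, or a plain hydroxyl group on the same aromatic carbon, would fit this position as well as methyl and butoxy do.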